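The source may hold more compounds than are shown below. What is called first, only, known or untested is meant among the compounds shown, and "the series" means these compounds.

The study looks at two measured compounds and one still to come, all read in a functional assay on HepG2 cells (Homo sapiens) for antiproliferative activity, read by MTT assay, with a stated time of 72 h; on this read-out lower numbers stand for stronger inhibition and higher numbers for weaker inhibition. Compound 1 `O=c1nc2oc(CCCCl)cc2cn1Cc1cn(-c2ccccc2F)nn1` gives 79800 nM in this assay. Compound 2 `CCCCCCC#Cc1c(CCCCCC)oc2nc(=O)n(Cc3cn(-c4ccc(F)cc4)nn3)cc12` is reported in this assay only as a limit of > 100000 nM, so no number is known for it. That limit is the one described by the limit of > 100000 nM in this assay, at which 1 of the 2 values shown sits, and it leaves compound 2 without a measured step to any other compound.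

Compound 3 `CCCCCCC#Cc1c(CCCCCC)oc2nc(=O)n(Cc3cn(Cc4ccccc4)nn3)cc12` shares the core of compound 2 and differs from it by benzyl in place of 4-fluorophenyl on an aromatic nitrogen. For the measured compounds named here, no measured step covers such a change here. With compound 2 sitting at a limit and compound 1 already weak, the expected step of a number no higher from compound 2 to compound 3 (the limit leaves the size open) is none beyond the scatter. Compound 3 is therefore estimated at 100000 nM in this assay, within a range from 40000 nM to 250000 nM.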

Compound 3, half-maximal inhibitory concentration: 25800 nM
Compound 3: the middle estimate sits 3.9-fold (0.59 log units) above what was measured; measured number outside the range, below it.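

In this assay, benzyl in place of 4-fluorophenyl on an aromatic nitrogen gives an at least 3.8-fold lower number from compound 2 to compound 3 (0.58 log units; beyond the scatter), which shows that the number responds to the group at this position, something compound 1 and compound 2 could not show. The two groups have the same count of heavy atoms and each holds one six-membered aromatic ring of carbon only, so the step comes without a change in those counts. The size of the step is only a bound, since compound 2 carries a limit and not a number: the limit of > 100000 nM in this assay, at which 1 of the 3 values shown sits.

The change replaces a fluorine and adds a carbon at once, and the compounds shown do not separate the two. Also open, from the compounds shown here alone, is how phenethyl or a plain phenyl would read at this position, and whether the same step holds on the core of compound 1.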